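The compounds below may be only part of what the source reports. "The series", "measured", "known", "first", "only" and "open" are said of these compounds alone.

Measured so far in an assay on isolated protein for inhibition of ubiquitin carboxyl-terminal hydrolase 7 (Homo sapiens), with stated times of 30 min and 2 h; a higher number here means a weaker inhibitor, a lower number a stronger inhibitor:
Compound 1, `Cn1nc2c(=O)n(CC3(O)CCN(Cc4ccc(C5CCCO5)cc4Cl)CC3)cnc2c1-c1ccc(CN)cc1`: compound 1 gives 3820 nM.
Compound 2, `Cn1nc2c(=O)n(CC3(O)CCN(Cc4ccc(-c5ccco5)cc4Cl)CC3)cnc2c1-c1ccc(C(=N)N)cc1`: compound 2 gives 87.5 nM.
Compound 3, `CCCNCc1ccc(-c2c3ncn(CC4(O)CCN(Cc5ccc(-c6ccco6)cc5Cl)CC4)c(=O)c3nn2C)cc1`: compound 3 gives 43.9 nM.

Compound 1 has the highest number of the three; compound 2 is nearest and compound 3 furthest, both gaps being beyond the scatter. Compound 4, `Cn1nc2c(=O)n(CC3(O)CCN(Cc4ccc(-c5cncs5)cc4Cl)CC3)cnc2c1-c1ccc(CN)cc1`, differs from compound 1 in one place: 1,3-thiazol-5-yl in place of oxolan-2-yl on an aromatic carbon.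

Going by the values given here, only one single-place step is available, a 2.0-fold lower number from compound 2 to compound 3 (0.30 log units; within the scatter), and it concerns the substituent on the other aryl ring, not the position changed here. Among the compounds with values here, no measured pair differs from another only at the place where oxolan-2-yl is exchanged; compounds 2 and 3 differ from compound 1 at two places at once, so their much lower numbers cannot be assigned to either place. The expectation for compound 4 in this assay therefore rests on little, and a move in either direction of moderate size is plausible. The estimate for compound 4 is 1500 nM, range 300 nM to 6000 nM, with the expected step being a 2.5-fold lower number from compound 1 to compound 4 (0.41 log units; beyond the scatter).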

Compound 4, half-maximal inhibitory concentration: 117 nM
Compound 4: the middle estimate sits 13-fold (1.11 log units) above what was measured, outside the stated range (below it).
By their numbers in this assay, from the lowest: compounds 3, 2 and 4 (each within the scatter of the next, the first and the last beyond it); then compound 1.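

In this assay, going by these compounds alone, 1,3-thiazol-5-yl in place of oxolan-2-yl gives a 33-fold lower number from compound 1 to compound 4 (1.51 log units; beyond the scatter), the first reading of this position with the rest of the structure unchanged. The position on the six-membered aromatic ring, para to a large group, is therefore far from indifferent to the group it carries, even though the two groups have the same heavy-atom count and differ in ring type, hetero atoms and acceptor count. No measurement bears on what lies behind the step.

Going by these compounds, it remains open whether a phenyl or cyclopentyl ring at this place would read closer to compound 1 or compound 4, which would help separate aromatic ring from hetero atoms. Also open, on these data alone, is whether the step holds with a propylaminomethyl or amidine group on the other aryl ring.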